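Swapping the Amine Substituent in a Cytotoxicity Series

The source may report more compounds than this note shows. Statements on the series, on what has been measured and on what is new or still open speak of the compounds shown alone.

Compound 1 `CCS(=O)(=O)Nc1ccc2c(c1)/C(=C(/NC1CCN(C)CC1)c1ccccc1)C(=O)N2` was examined in an ADME assay on HepG2 cells (Homo sapiens) for cytotoxicity, read by MTT assay, with a stated time of 48 h; on this read-out higher numbers stand for lower toxicity in this test and lower numbers for higher toxicity in this test. In this assay compound 1 gives > 10 uM, which is a limit of the assay rather than a number. A second compound, compound 2 `CCS(=O)(=O)Nc1ccc2c(c1)/C(=C(\C)Nc1ccc(CN3CCCCC3)cc1)C(=O)N2`, was examined in the same way. In this assay compound 2 gives > 6 uM, again a limit and not a measured value. Compound 1 thus stands at one of the two limits recorded (the limit of > 10 uM in this assay, at which 1 of the 2 values shown sits), while the other limit sits at a different level (the limit of > 6 uM in this assay, at which 1 of the 2 values shown sits). Going by the values given here, with only limits in hand, no step between measured compounds can be counted. Compound 3 `CCS(=O)(=O)Nc1ccc2c(c1)/C(=C(/Nc1ccc(N3CCCCC3)cc1)c1ccccc1)C(=O)N2` differs from compound 1 in one place: 4-(piperidin-1-yl)phenyl in place of 1-methylpiperidin-4-yl on an amine nitrogen. Since both known values are limits, no direction for this change can be read from them, and a step no larger than the usual scatter is expected. Compound 3 is expected to give 15 uM in this assay, within a range from 5 uM to 50 uM. The estimated step is a step that the limit leaves unreadable from compound 1 to compound 3.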

Compound 3, half-maximal toxic concentration: > 6 uM
Compound 3: only a limit was reported; the forecaster's own chance of this, stated with the estimate: 65%; the middle value is on the limit's open side.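

In this assay compound 3 gives > 6 uM, which is a limit and not a number. Going by these compounds alone, compound 1 also stands at a limit, and no step from compound 1 to compound 3 can be read. The compounds shown leave open whether 4-(piperidin-1-yl)phenyl in place of 1-methylpiperidin-4-yl on an amine nitrogen changes the read-out at all.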